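Swapping phenyl for furan-2-yl on the imine carbon

The source may hold more compounds than are shown below. What is called first, only, known or untested is meant among the compounds shown, and "the series" means these compounds.

Compound 1 `CCOC(=O)c1c(N)sc(/N=C/c2ccccc2)c1C(=O)OCC` is the stronger of the two measured compounds in a functional assay on HeLa cells (Homo sapiens) for inhibition, read by MTT assay, with a stated time of 48 h (on this read-out higher numbers stand for weaker inhibition and lower numbers for stronger inhibition), giving 31200 nM, while compound 2 `CCOC(=O)c1c(N)sc(/N=C/c2ccc(OC)cc2)c1C(=O)OCC` gives 189000 nM. Within the data shown here, the only measured step, a 6.1-fold higher number from compound 1 to compound 2 (0.78 log units; beyond the scatter), adds a group onto the phenyl rather than exchanging the ring itself. Compound 3 `CCOC(=O)c1c(N)sc(/N=C/c2ccco2)c1C(=O)OCC` differs from compound 1 by furan-2-yl in place of phenyl on a carbon with a double bond to nitrogen. Among the measured compounds shown here, no measured step bears directly on this exchange, so no step beyond the scatter is expected. Compound 3 is therefore estimated at 40000 nM, within a range from 12000 nM to 130000 nM, which means a 1.3-fold higher number from compound 1 to compound 3 (0.11 log units; within the scatter).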

Compound 3, half-maximal inhibitory concentration: 46700 nM
Beside the measured number, compound 3's estimate is 1.2-fold (0.07 log units) below it, within the range that was stated.
By their numbers in this assay, from the lowest: compounds 1 and 3 (each within the scatter of the next); then compound 2.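

In this assay, furan-2-yl in place of phenyl on a carbon with a double bond to nitrogen gives a 1.5-fold higher number from compound 1 to compound 3 (0.18 log units; within the scatter), so a smaller ring holding an oxygen reads the same as phenyl here. Furan-2-yl in place of 4-methoxyphenyl at that carbon gives a 4.0-fold lower number from compound 2 to compound 3 (0.61 log units; beyond the scatter), which leaves compound 3 level with compound 1 and clearly apart from compound 2.

From the compounds shown here alone, whether a thiophene or pyridine ring on this carbon would read like furan-2-yl remains open. Nothing available explains either step.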